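The source may hold more compounds than are shown below. What is called first, only, known or untested is meant among the compounds shown, and "the series" means these compounds.

Among the compounds with values here, compound 2 `Cc1ccc(C(=O)NCc2cccc(Cn3cnc4ccccc43)c2)cc1` has the lower of the two numbers measured so far in an assay for inhibition of Indoleamine 2,3-dioxygenase 1 (Homo sapiens), read by HPLC, with a stated time of 48 h; on this read-out higher numbers stand for weaker inhibition and lower numbers for stronger inhibition: compound 2 gives 327 nM. The other measured compound, compound 1 `O=C(NCc1cccc(Cn2cnc3ccccc32)c1)c1cc2cc(O)ccc2[nH]1`, gives 781 nM in this assay. Within the data shown here, the single measured step between them is a 2.4-fold lower number from compound 1 to compound 2 (0.38 log units; beyond the scatter), a change of the whole group attached to the carbonyl carbon rather than of a single substituent on a ring.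

Compound 3 `O=C(NCc1cccc(Cn2cnc3ccccc32)c1)c1ccc(Cl)cc1` is not yet measured. It differs from compound 2 by chloro in place of methyl on an aromatic carbon. Among the measured compounds shown here, the one measured step does not bear on this change, since it exchanged an entire ring system on the carbonyl, whereas here only one small group on the six-membered ring is swapped for another of the same size. For the measured compounds named here, nothing among the measured compounds shows what such an exchange does, so no step beyond the scatter is expected in this assay. The step expected for compound 3 is a 1.1-fold lower number from compound 2 to compound 3 (0.04 log units; within the scatter). Compound 3 is therefore estimated at 300 nM in this assay, with a range from 120 nM to 800 nM.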

Compound 3, half-maximal inhibitory concentration: 477 nM
Beside the measured number, compound 3's estimate is 1.6-fold (0.20 log units) below it; measured number inside the range.
By their numbers in this assay, from the lowest: compounds 2, 3 and 1 (each within the scatter of the next, the first and the last beyond it).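

In this assay, placing chloro instead of methyl on the aromatic carbon para to a large group gives a 1.5-fold higher number from compound 2 to compound 3 (0.16 log units; within the scatter) and so, for the first time among these compounds, tests a swap of one heavy atom for another at this position; the two groups cannot be told apart here. The comparison with the compound carrying 5-hydroxy-1H-indol-2-yl on the carbonyl adds a second point: the 4-methylphenyl exchange gave a 2.4-fold lower number from compound 1 to compound 2 (0.38 log units; beyond the scatter) while the 4-chlorophenyl exchange gives a 1.6-fold lower number from compound 1 to compound 3 (0.21 log units; within the scatter) and so the clear gap seen earlier does not hold for both groups on the six-membered ring, even though those two groups cannot themselves be separated. Nothing available explains why these numbers fall as they do.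

Methyl and chloro are the only groups shown at this position, so it remains open whether a methoxy group, an amine or a carboxylic acid there would shift the number beyond the scatter. Also open, on these data alone, is what either group would do on another carbon of the same six-membered ring.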